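This account rests on a few compounds, and the source may have more. Where it says the series, first, only, none or still open, it means among the compounds named here.

Three compounds have been measured in a functional assay on T47D cells (Homo sapiens) for cytotoxicity, read by sulforhodamine B assay, with a stated time of 48 h; on this read-out higher numbers stand for lower toxicity in this test and lower numbers for higher toxicity in this test:

Compound 1 `ClCc1ccccc1Cn1cnc2c(Cl)nc(Cl)nc21` — > 100000 nM
Compound 2 `ClCc1ccccc1Cn1cnc2c(Cl)ncnc21` — > 100000 nM
Compound 3 `ClCc1cccc(Cn2cnc3ncnc(Cl)c32)c1` — 2880 nM

The value for compound 1 is a limit of the assay, not a number. The value for compound 2 is likewise a limit. Compound 3 alone gives a number in this assay. Compound 2 and compound 3 hold the same atoms joined differently; the difference between the two cores is not broken down here. From compound 2 to compound 1 the change is chloro in place of hydrogen on an aromatic carbon, and the step that the two limits leave unreadable from compound 2 to compound 1 cannot be read because of the limit of > 100000 nM in this assay, at which 2 of the 3 values shown sit.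

Compound 4 `ClCc1cccc(Cn2cnc3nc(Cl)nc(Cl)c32)c1` has not yet been measured. It differs from compound 3 by chloro in place of hydrogen on an aromatic carbon, the same change as that from compound 2 to compound 1. Since that earlier step has no readable size, the value of compound 4 is expected to lie close to that of compound 3, estimated at 4000 nM with a range from 1000 nM to 30000 nM. This expectation means a step of a 1.4-fold higher number from compound 3 to compound 4 (0.14 log units; within the scatter).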

Compound 4, concentration lethal to 50% of the cells: > 100000 nM
Compound 4: a limit, no number; the forecaster's own chance of this, stated with the estimate: 25%; at least 25-fold (1.39 log units) between middle value and limit.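

In this assay, chloro in place of hydrogen on an aromatic carbon gives an at least 34-fold higher number from compound 3 to compound 4 (1.54 log units; beyond the scatter), so on the core of compound 3 this change has a large effect. Compound 4 gives > 100000 nM, which is a limit of the assay and not a number. The same change on the other core, from compound 2 to compound 1, cannot be read, so the data do not show whether the effect carries from one core to the other, because both of those compounds sit at the limit: the limit of > 100000 nM in this assay, at which 3 of the 4 values shown sit.

As far as these compounds go, it remains open whether an amine or a methoxy group, in place of the chloro between two ring nitrogen atoms, would keep a readable number on the core of compound 3.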